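Changing One Sulfur Side Group

This account rests on a few compounds, and the source may have more. Where it says the series, first, only, none or still open, it means among the compounds named here.

In a functional assay on HeLa cells (Homo sapiens) for cytotoxicity, read by resazurin assay, with a stated time of 72 h (a lower number here means a stronger inhibitor, a higher number a weaker inhibitor), compound 1 `COCCSC(=S)SCC(=O)c1ccc(OC)cc1` gives 7880 nM and compound 2 `CCNC(=O)SCC(=O)c1ccc(OC)cc1` gives 13300 nM, so compound 2 stands within the usual scatter of compound 1. Compound 3 `CCOC(=S)SCC(=O)c1ccc(OC)cc1` is still unmeasured and differs from compound 2 only on a sulfur: a group of 5 heavy atoms (3 carbon, 1 oxygen, 1 sulfur; no ring) in place of a group of 5 heavy atoms (3 carbon, 1 nitrogen, 1 oxygen; no ring), on a sulfur. Within the data shown here, no measured step shows what such a swap does, but the different groups on that sulfur in compound 1, at 7880 nM, and compound 2, at 13300 nM, suggest a small shift. The expected change is a 1.4-fold lower number from compound 2 to compound 3 (0.15 log units; within the scatter), towards a lower number but not clearly beyond the scatter. For compound 3, the estimated value is 9500 nM, within a range of 4000 nM to 22000 nM.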

Compound 3, half-maximal inhibitory concentration: 4640 nM
The estimate for compound 3 lay 2.0-fold (0.31 log units) above the measured number; the range from low to high includes it.
By their numbers in this assay, from the lowest: compounds 3, 1 and 2 (each within the scatter of the next, the first and the last beyond it).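

In this assay, swapping the ethylcarbamoyl group on this sulfur for the group in compound 3 gives a 2.9-fold lower number from compound 2 to compound 3 (0.46 log units; beyond the scatter), showing that the choice of group here can shift the number beyond the scatter. On the thiocarbonyl carbon, ethoxy in place of (2-methoxyethyl)sulfanyl gives a 1.7-fold lower number from compound 1 to compound 3 (0.23 log units; within the scatter), a step that cannot be told apart from scatter. Nothing available explains the larger step. Going by these compounds, the swap alters several atoms at once, so the part that matters remains unknown. An ethylamino group on the thiocarbonyl carbon would separate the nitrogen from the thiocarbonyl sulfur, while a longer chain in place of ethoxy remains an open test.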